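Adding a methylpiperazine to compound 2

The compounds below may be only part of what the source reports. "The series", "measured", "known", "first", "only" and "open" are said of these compounds alone.

In a functional assay on K562 cells (Homo sapiens) for antiproliferative activity, read by MTT assay, with a stated time of 72 h (a lower number here means a stronger inhibitor, a higher number a weaker inhibitor), compound 1 `CN1CCN(c2cccc(C(=O)/C=C/c3ccc(/C=C/C(=O)NO)cc3)c2)CC1` gives 850 nM and compound 2 `O=C(/C=C/c1ccc(/C=C/C(=O)c2ccccc2)cn1)NO` gives 690 nM, two values within the scatter of each other. For the measured compounds named here, compound 2 therefore stands level with the only other measured compound. Compound 3 `CN1CCN(c2ccccc2C(=O)/C=C/c2ccc(/C=C/C(=O)NO)nc2)CC1` is compound 2 with 4-methylpiperazin-1-yl in place of hydrogen on an aromatic carbon of a six-membered aromatic ring of carbon only, ortho to a large group: 4-methylpiperazin-1-yl in place of hydrogen on an aromatic carbon. Going by the values given here, no measured pair isolates this change. Compound 1 also carries 4-methylpiperazin-1-yl on an aromatic carbon, at 850 nM on its own core, so no shift beyond the scatter is expected in this assay here. The estimated 1.3-fold higher number from compound 2 to compound 3 (0.12 log units; within the scatter) is slightly upward and stays inside the scatter. The estimated value for compound 3 is 900 nM with an expected range from 300 nM to 2700 nM as the likely span.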

Compound 3, half-maximal inhibitory concentration in the K562 assay: 1220 nM
Estimate against measurement, compound 3: 1.4-fold (0.13 log units) below, within the range that was stated.
By their numbers in the K562 assay, from the lowest: compounds 2, 1 and 3 (each within the scatter of the next).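

For the compounds shown here, this pair gives the first direct reading of 4-methylpiperazin-1-yl in place of hydrogen on an aromatic carbon, ortho to a large group, which the earlier compounds could not isolate. In the K562 assay, the change gives a 1.8-fold higher number from compound 2 to compound 3 (0.25 log units; within the scatter), so at this position the group leaves the antiproliferative read-out without a shift that can be told from the scatter. The same change is large in a physicochemical assay for solubility, at pH 7.4 (a lower number here means a less soluble compound, a higher number a more soluble compound), where compound 2 gives 27000 nM and compound 3 gives 469000 nM so here it separates the two read-outs, moving only one of them beyond the scatter: the measured solubility of compound 2, 27000 nM, and of compound 3, 469000 nM, a 17-fold higher number (1.24 log units; beyond the scatter)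

Going by these compounds, it remains open whether 4-methylpiperazin-1-yl would give the same pairing of results at other places on this ring. On these data alone, it is also open whether a morpholine, a dimethylamine or a carboxylic acid at this same position would do so.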